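This account rests on a few compounds, and the source may have more. Where it says the series, first, only, none or still open, it means among the compounds named here.

Compound 1 `Cc1cccc(-c2noc([C@H](C)NC(=O)c3cc(C4CC4)n(C)n3)n2)c1` in an assay on T-REx-293 cells for inhibition of potassium channel subfamily T member 1 (Homo sapiens), read by patch clamp (a lower number here means a stronger inhibitor, a higher number a weaker inhibitor), reaches only a limit, > 30000 nM, which is the limit of > 30000 nM in this assay, at which 1 of the 2 values shown sits. For the measured compounds named here, compound 2 `C[C@H](NC(=O)c1cc(C(F)(F)F)nn1C)c1nc(-c2ccncc2)no1` in this assay gives 5250 nM; that is the only number in the set. Compound 3 `C[C@H](NC(=O)c1cc(C(F)(F)F)nn1C)c1nc(-c2ccnc(C(F)(F)F)c2)no1` differs from compound 2 by trifluoromethyl in place of hydrogen on an aromatic carbon. Going by the values given here, no measured pair shows this change, so the size of the step rests on expectation alone. A modest gain in potency is expected, close to the edge of the scatter, and a 1.8-fold lower number from compound 2 to compound 3 (0.24 log units; within the scatter) is the estimated step. Compound 3 is expected at 3000 nM, with a range of 800 nM to 12000 nM.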

Compound 3, half-maximal inhibitory concentration: 40 nM
Beside the measured number, compound 3's estimate is 75-fold (1.88 log units) above it, outside the stated range (below it).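

For the compounds shown here, the change from pyridin-4-yl to 2-(trifluoromethyl)pyridin-4-yl gives the only single-place comparison so far: a 130-fold lower number from compound 2 to compound 3 (2.12 log units; beyond the scatter) in this assay. Going by these compounds alone, the aromatic carbon next to the ring nitrogen is therefore a place where one substituent moves potency well beyond the scatter, which the earlier compounds, with no single-place pair between them, could not show. Nothing shown here accounts for the size of this step.

From the compounds shown here alone, whether a methyl, a chlorine or a nitrile at this carbon would give a similar step remains open. So does the effect of trifluoromethyl at the other carbons of this ring.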